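The source may report more compounds than this note shows. Statements on the series, on what has been measured and on what is new or still open speak of the compounds shown alone.

Measured so far in an ADME assay on HepG2 cells (Homo sapiens) for cytotoxicity, read by CellTiter-Glo and resazurin assay, with a stated time of 72 h; on this read-out lower numbers stand for an effect already at smaller amounts and higher numbers for an effect only at larger amounts of compound:
Compound 1 `CC(C)Oc1cccc(-c2ccc(C(=O)N(Cc3cccc(OCCCCCC(=O)O)c3)C(C)C)cc2)c1`, for which this assay gives > 26000 nM.
Compound 2 `CCOc1cccc(-c2ccc(C(=O)N(Cc3cccc(OCCCCCC(=O)O)c3)C(C)C)cc2)c1`, for which this assay gives > 20800 nM.
Compound 3 `CCOC(=O)CCCCCOc1cccc(CN(C(=O)c2ccc(-c3cccc(OC(C)C)c3)cc2)C(C)C)c1`, for which this assay gives > 26000 nM.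

Each of these three values is a limit of this assay, not a number. Compound 3 stands at such a limit, and the two other values shown are limits as well. The step that the two limits leave unreadable from compound 1 to compound 2 is therefore not readable, and the step that the two limits leave unreadable from compound 1 to compound 3 is not readable either; the values sit at the limit of > 20800 nM in this assay, at which 1 of the 3 values shown sits, and at the limit of > 26000 nM in this assay, at which 2 of the 3 values shown sit.

Compound 4 `CCOC(=O)CCCCCOc1cccc(CN(C(=O)c2ccc(-c3cccc(F)c3)cc2)C(C)C)c1` differs from compound 3 by fluoro in place of isopropoxy on an aromatic carbon. Going by the values given here, no measured step bears on this change, and the measured steps themselves carry no readable size. What the series shows is only that none of the three compounds reached an effect within the range covered. For compound 4 the step of a number no higher from compound 3 to compound 4 (the limit leaves the size open) is expected to stay within the scatter, and the estimate for compound 4 in this assay is 26000 nM, with a range from 10000 nM to 60000 nM, most likely reported again as a limit.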

Compound 4, half-maximal effective concentration: > 26000 nM
Compound 4 gave a limit, no number (the forecaster's own chance of this, stated with the estimate: 80%); the middle value sits exactly at the limit.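

Compound 3 and compound 4 both give only a limit in this assay, so no step between them can be read; they sit at the same limit: the limit of > 26000 nM in this assay, at which 3 of the 4 values shown sit.

The compounds shown leave open at what concentration compound 1, compound 2, compound 3 or compound 4 would reach a half-maximal effect in this assay.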